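A few compounds are considered here, and "the series" means these few. Any claim that something is new, unique, unknown or untested is made for them only; others in the source may bear on it.

Compound 1 `O=S(=O)(c1ccccc1)c1nc2ccccc2nc1Nc1ccccc1` gives 22600 nM in a functional assay on KB cells (Homo sapiens) for cytotoxicity, read by MTT assay, with a stated time of 72 h; on this read-out lower numbers stand for stronger inhibition and higher numbers for weaker inhibition. Compound 3 `Cc1ccc(S(=O)(=O)c2nc3ccccc3nc2Nc2ccccc2)cc1` gives 19000 nM in this assay, and the change between them, methyl in place of hydrogen on an aromatic carbon, yields a 1.2-fold lower number from compound 1 to compound 3 (0.08 log units; within the scatter). For compound 2 `COc1cc(Nc2nc3ccccc3nc2S(=O)(=O)c2ccccc2)cc(OC)c1` the outcome in this assay is recorded as "not determined" (no result reported). Among the two numbers, compound 3 holds the lower one, yet its gap to compound 1 lies within the scatter, so no order between the two can be read.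

Compound 4 `Cc1ccc(S(=O)(=O)c2nc3ccccc3nc2Nc2cccc(N)c2)cc1` differs from compound 3 by amino in place of hydrogen on an aromatic carbon. Among the measured compounds shown here, no measured step touches this part of the molecule; the one step available, a 1.2-fold lower number from compound 1 to compound 3 (0.08 log units; within the scatter), concerns a different part and stayed within the scatter, so it gives no direction for the new change. Compound 4 is therefore expected to sit close by, with a step of a 1.3-fold lower number from compound 3 to compound 4 (0.10 log units; within the scatter) and an estimated value of 15000 nM, ranging from 5000 nM to 45000 nM in this assay.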

Compound 4, half-maximal inhibitory concentration: 10600 nM
Estimate against measurement, compound 4: 1.4-fold (0.15 log units) above; the range from low to high includes it.
By their numbers in this assay, from the lowest: compounds 4, 3 and 1 (each within the scatter of the next, the first and the last beyond it).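

Among the compounds shown here, with compound 4, the ring carrying the anilino nitrogen is probed for the first time, as the earlier step concerned a different part of the molecule. On this six-membered aromatic ring, amino in place of hydrogen, meta to a large group, gives a 1.8-fold lower number from compound 3 to compound 4 (0.25 log units; within the scatter) in this assay, so this position accepts a hydrogen-bond donor without a difference that can be told from the scatter. No measurement shown here explains this result.

Going by these compounds, whether a carboxylic acid or an acetamide in place of the amino group would move the number beyond the scatter remains open. Also open, on these data alone, is whether the amino group would behave the same way in compound 1, and compound 2, with no reported result, offers no reading for methoxy on this ring.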